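The compounds below may be only part of what the source reports. "The series", "measured", "known", "first", "only" and "open" are said of these compounds alone.

Of the compounds shown here, two with the same core have been measured so far in an ADME assay on microsomes from liver (Homo sapiens) for metabolic stability, read by LC-MS, with a stated time of 1 h; on this read-out higher numbers stand for a more stable compound and lower numbers for a less stable compound. Compound 1 (`O=[N+]([O-])c1cn2c(n1)OC[C@@H](OCc1ccc(-c3ccc(CNc4ccccc4)cc3)cc1)C2`) gives 12% and compound 2 (`CC(=O)c1ccc(-c2ccc(CO[C@@H]3COc4nc([N+](=O)[O-])cn4C3)cc2)cc1`) gives 36% as the higher of the two numbers. Compound 3 (`O=[N+]([O-])c1cn2c(n1)OC[C@@H](OCc1ccc(-c3ccc(Oc4ccccc4)cc3)cc1)C2`) has not yet been measured. It differs from compound 2 by phenoxy in place of acetyl on an aromatic carbon, para to a large group, and the counted difference is phenoxy in place of acetyl on an aromatic carbon at that place. For the measured compounds named here, the only measured step that bears on this change is a number 24 percentage points higher from compound 1 to compound 2 (beyond the scatter) with acetyl in place of anilinomethyl on an aromatic carbon, and it is modest. Compound 3 loses the same acetyl, and like compound 1 it carries a six-membered aromatic ring of carbon only within the group at this place. One step cannot show how phenoxy itself will behave, so only a cautious reading is possible. A modest fall is expected, and the estimated step is a number 14 percentage points lower from compound 2 to compound 3 (beyond the scatter) in size, somewhat smaller than the measured one. Compound 3 is estimated at 22% with a range from 8% to 42% as the expected span.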

Compound 3, percent of the compound remaining: 22%
The estimate for compound 3 equals the measured number at the digits printed, within the range that was stated.
By their numbers in this assay, from the lowest: compounds 1 and 3 (each within the scatter of the next); then compound 2.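

In this assay, the place on an aromatic carbon, para to a large group, has now carried three different groups, and the new result shows that acetyl keeps its lead over a second group holding a six-membered aromatic ring of carbon only: phenoxy in place of acetyl gives a number 14 percentage points lower from compound 2 to compound 3 (beyond the scatter) and so joins the earlier step from anilinomethyl to acetyl as a change beyond the scatter. Phenoxy in place of anilinomethyl gives a number 10 percentage points higher from compound 1 to compound 3 (within the scatter) and so does not separate these two ring-bearing groups, which means that the different link to the ring, oxygen in one and a chain with nitrogen in the other, shows no change that can be told from the scatter on this read-out. No measurement is at hand that would explain either step.

For the compounds shown here, with only three groups at this place, acetyl is the sole group without a ring, and a single compound cannot show whether the absence of a ring or something particular to acetyl goes with its number. On these data alone, a carboxylic acid, a methyl ketone on a longer chain or a saturated cyclohexyl ring at the same place would be needed to tell these readings apart, and how any of them would fall remains open.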